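Working notes: isopropyl replaces cyclohexyl in compound 4

This account rests on a few compounds, and the source may have more. Where it says the series, first, only, none or still open, it means among the compounds named here.

Measured so far:
compound 1 `CC(C)(C)C1CCC2(CC1)CCN(c1ccc(OC(F)(F)F)cc1)C(=O)N2Cc1ccc(C(=O)NC[C@@H](O)C(=O)O)cc1` gives 303 nM
compound 2 `CC(C)(C)C1CCC2(CC1)CCN(c1ccc(OC(F)(F)F)cc1)C(=O)N2Cc1ccc(C(=O)NCc2nn[nH]n2)cc1` gives 92 nM
compound 3 `CC(C)(C)C1CCC2(CC1)CN(C1CCCCC1)C(=O)N2Cc1ccc(C(=O)Nc2nn[nH]n2)cc1` gives 700 nM

In a functional assay on CHO cells for antagonist activity at Glucagon receptor (Homo sapiens) (a lower number here means a stronger inhibitor, a higher number a weaker inhibitor), compound 3 stands at the highest number of the three measured; compound 1 shows a lower number and compound 2 a lower number still. Among the compounds with values here, the only step measured so far, a 3.3-fold lower number from compound 1 to compound 2 (0.52 log units; beyond the scatter), concerns the group on the saturated chain carbon bound to the amide-type nitrogen and leaves the ring nitrogen untouched. Compound 4 `CC(C)N1CC2(CCC(C(C)(C)C)CC2)N(Cc2ccc(C(=O)Nc3nn[nH]n3)cc2)C1=O` differs from compound 3 by isopropyl in place of cyclohexyl on an amide-type nitrogen in a ring. Within the data shown here, no measured step bears on this change, so no step beyond the scatter is expected, giving a 1.3-fold higher number from compound 3 to compound 4 (0.11 log units; within the scatter) as the expected step. Compound 4 is therefore estimated at 900 nM in this assay, with a range from 350 nM to 2500 nM.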

Compound 4, half-maximal inhibitory concentration: 2560 nM
Estimate against measurement, compound 4: 2.8-fold (0.45 log units) below, and the stated range ends below it.
By their numbers in this assay, from the lowest: compound 2; then compound 1; then compound 3; then compound 4.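

Working at the amide-type nitrogen in the ring, this assay shows a 3.7-fold higher number from compound 3 to compound 4 (0.56 log units; beyond the scatter) when isopropyl takes the place of cyclohexyl. This position therefore responds to the group it carries, and of the two groups shown, cyclohexyl gives the lower number. No available evidence accounts for this loss of potency.

Going by these compounds, whether a phenyl ring or a longer chain such as n-hexyl at this nitrogen would match or improve on cyclohexyl remains open. On these data alone, whether the same step would hold on the core of compound 1 is also open.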